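Chloro for amino on the shared core: cytotoxicity notes

The source may report more compounds than this note shows. Statements on the series, on what has been measured and on what is new or still open speak of the compounds shown alone.

Measured compounds:
compound 1 `Nc1nc2cc(Cl)c(Cl)cc2n1Cc1cccc(Cl)c1` — 37000 nM
compound 2 `Nc1nc2cc(Cl)c(Cl)cc2n1Cc1ccccc1Cl` — 36000 nM
compound 3 `Clc1cccc(Cn2c(Cl)nc3cc(Cl)c(Cl)cc32)c1` — a limit of the assay, > 100000 nM

In a functional assay on CEM-SS cells (Homo sapiens) for cytotoxicity (a higher number here means a weaker inhibitor, a lower number a stronger inhibitor), compound 1 gives 37000 nM and compound 2 gives 36000 nM; the two sit within the scatter of each other, so no order between them is claimed. The cores of compound 1 and compound 2 hold the same atoms joined differently, and the difference between the two cores is not broken down here. For compound 3 this assay reports only a limit, > 100000 nM. The change chloro in place of amino on an aromatic carbon gave the step of an at least 2.7-fold higher number from compound 1 to compound 3 (0.43 log units; beyond the scatter), a measured step whose size is bounded because compound 3 rests at the limit (the limit of > 100000 nM in this assay, at which 1 of the 3 values shown sits).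

Compound 4 `Clc1cc2nc(Cl)n(Cc3ccccc3Cl)c2cc1Cl` carries the same change made on compound 2: chloro in place of amino on an aromatic carbon. The place lines of the two changes agree word for word, so it is counted as the same change. Resting on the step of an at least 2.7-fold higher number from compound 1 to compound 3 (0.43 log units; beyond the scatter), the step from compound 2 to compound 4 is expected to be a 4.2-fold higher number from compound 2 to compound 4 (0.62 log units; beyond the scatter). Compound 4 is estimated at 150000 nM, with a real chance that this assay again returns only a limit.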

Compound 4, half-maximal inhibitory concentration: 70000 nM
For compound 4 the middle estimate is 2.1-fold (0.33 log units) above the measured one; measured number inside the range.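

Chloro in place of amino on an aromatic carbon gives a 1.9-fold higher number from compound 2 to compound 4 (0.29 log units; within the scatter) in this assay, so on this core the change is not resolved from the scatter. Set beside the step on the core of compound 1, the two results cannot be separated: the same change on two cores in this assay, an at least 2.7-fold higher number (0.43 log units; beyond the scatter) from compound 1 to compound 3 and a 1.9-fold higher number (0.29 log units; within the scatter) from compound 2 to compound 4; the limit leaves it open whether they differ. The value of compound 3, > 100000 nM, is a limit of the assay and not a number, so these results neither confirm nor rule out that the change carries over from one core to the other with the same size.

Open, going by these compounds, is how a methyl, a methoxy or a longer amine chain would read in this assay on that aromatic carbon between two ring nitrogen atoms. Also open, on these data alone, is whether the change reads alike on cores that carry fluoro in place of the other chloro groups.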